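A Chloro Added to the Benzyl Group of Compound 2

The source may report more compounds than this note shows. Statements on the series, on what has been measured and on what is new or still open speak of the compounds shown alone.

Among the measured compounds shown here, compound 2 `CC1CCCC(Nc2ncnc3c2nnn3Cc2ccccc2)C1` gives 770 nM in an assay on cell membranes for binding affinity to adenosine receptor A1 (Bos taurus), read by radioligand binding (on this read-out lower numbers stand for stronger inhibition and higher numbers for weaker inhibition), the higher of the two numbers measured so far. Compound 1 `Clc1ccccc1Cn1nnc2c(NC3CCCC3)ncnc21` gives 21 nM in this assay; these two compounds differ in more than one place, so their values are set side by side only as they stand. Compound 3 `CC1CCCC(Nc2ncnc3c2nnn3Cc2ccccc2Cl)C1` has not yet been measured. It arises from compound 2 by chloro in place of hydrogen on an aromatic carbon. For the measured compounds named here, no step between measured compounds that differ in a single place is available, so the size of this change in this assay has to be judged from the values alone. Compound 1, which also carries the 2-chlorobenzyl group, shows the far lower number of 21 nM, so a move toward stronger binding appears plausible, although the second difference between compound 1 and compound 2 cannot be separated from it. The step from compound 2 to compound 3 is expected to be a 3.9-fold lower number from compound 2 to compound 3 (0.59 log units; beyond the scatter). Compound 3 is estimated at 200 nM, within a range from 50 nM to 800 nM.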

Compound 3, inhibition constant: 102 nM
For compound 3 the middle estimate is 2.0-fold (0.29 log units) above the measured one, within the range that was stated.
By their numbers in this assay, from the lowest: compound 1; then compound 3; then compound 2.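

In this assay, the change from benzyl to 2-chlorobenzyl can now be read on its own, and chloro in place of hydrogen on this aromatic carbon gives a clear gain (a 7.5-fold lower number from compound 2 to compound 3 (0.88 log units; beyond the scatter)). With the 2-chlorobenzyl group held constant, 3-methylcyclohexyl in place of cyclopentyl on the nitrogen gives a step the other way (a 4.9-fold higher number from compound 1 to compound 3 (0.69 log units; beyond the scatter)), so the chloro step alone does not span the whole gap between compound 2 and compound 1. Nothing available explains why either step has the size it does.

Going by these compounds, whether a fluoro or a methyl group in the same place would act as chloro does remains open. Also open is how large the chloro step would be with cyclopentyl on the nitrogen, since the compounds shown give it only with 3-methylcyclohexyl.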